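Hydroxy removal from compound 1, expected size of step

A few compounds are considered here, and "the series" means these few. Any claim that something is new, unique, unknown or untested is made for them only; others in the source may bear on it.

Compound 1 `CN(CCCOc1ccc(O)cc1)c1ccccc1` and compound 2 `CN(CCCCCOc1ccc(O)cc1)c1ccccc1` have been measured in a functional assay on HeLa cells (Homo sapiens) for cytotoxicity, read by MTT assay, with a stated time of 48 h; a higher number here means a weaker inhibitor, a lower number a stronger inhibitor. In this assay compound 1 gives 9000 nM, and compound 2 gives 13000 nM. Compound 1 has the lower of the two numbers, compound 2 the nearest, and the gap between them lies within the scatter, so the two are not told apart. Going by the values given here, no step between measured compounds that differ in one place is available.

Compound 3 `CN(CCCOc1ccccc1)c1ccccc1` is not yet measured in this assay. Relative to compound 1 the change is hydrogen in place of hydroxy on an aromatic carbon. The two measured compounds give no indication of how this change acts in this assay, and no step beyond the scatter is expected in either direction. Compound 3 is estimated at 12000 nM, with a range from 4000 nM to 40000 nM. The expected step of a 1.3-fold higher number from compound 1 to compound 3 (0.12 log units; within the scatter) is small and within the scatter.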

Compound 3, half-maximal inhibitory concentration: > 125000 nM
Compound 3: no number, only a limit; the forecaster's own chance of this, stated with the estimate: 20%; middle value at least 10-fold (1.01 log units) from the limit.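

In this assay, going by these compounds alone, hydrogen in place of hydroxy on an aromatic carbon, para to a large group, gives an at least 13-fold higher number from compound 1 to compound 3 (1.14 log units; beyond the scatter), the first step beyond the scatter and the first reading of this position. Compound 3 stands at > 125000 nM, which is a limit of the assay and not a number, so the step has a floor and no measured size: the limit of > 125000 nM in this assay, at which 1 of the 3 values shown sits. The hydroxy at this position therefore matters for the cytotoxicity of compound 1, and compound 1 and compound 2, which both carry it, gave no sign of this.

Open, as far as these compounds go, is whether a methoxy or an amine at this position would keep the value of compound 1. Also open, from the compounds shown here alone, is whether the same change on compound 2, with its longer chain, gives a step of like size.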